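This account rests on a few compounds, and the source may have more. Where it says the series, first, only, none or still open, it means among the compounds named here.

Measured in an assay on CHO cells for positive allosteric modulation of metabotropic glutamate receptor 5 (Homo sapiens), read by FLIPR; on this read-out lower numbers stand for an effect already at smaller amounts and higher numbers for an effect only at larger amounts of compound:
Compound 1 `O=C(Nc1ccc(F)cc1CN1C(=O)c2ccccc2C1=O)c1ccccn1` gives 1500 nM.
Compound 3 `Cc1ccc2c(c1C)C(=O)N(Cc1cc(Cl)ccc1NC(=O)c1ccccn1)C2=O` gives 2200 nM.
Compound 2 `O=C(Nc1ccc(Cl)cc1CN1C(=O)c2ccccc2C1=O)c1ccccc1` gives only a limit of the assay, > 100000 nM.

Compound 2 thus stands at the assay limit, (the limit of > 100000 nM in this assay, at which 1 of the 3 values shown sits), the weakest point of the three, whereas compound 1 and compound 3 give numbers within the scatter of each other. The next compound, compound 4 `O=C(Nc1ccc(Cl)cc1CN1C(=O)c2ccccc2C1=O)c1cncs1`, differs from compound 2 by 1,3-thiazol-5-yl in place of phenyl on a carbonyl carbon. Going by the values given here, no step between measured compounds is known, so the size of this change in this assay is open; a gain beyond the scatter is expected, since compound 2 sits only at the limit > 100000 nM and any reported number would already lie below it. The step from compound 2 to compound 4 is expected as an at least 16-fold lower number from compound 2 to compound 4 (1.22 log units; beyond the scatter). Compound 4 is estimated at 6000 nM, with a range from 800 nM to 50000 nM.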

Compound 4, half-maximal effective concentration: 1900 nM
The estimate for compound 4 lay 3.2-fold (0.50 log units) above the measured number; the range from low to high includes it.
By their numbers in this assay, from the lowest: compounds 1, 4 and 3 (each within the scatter of the next). At a limit, above all of these: compound 2.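

At the carbonyl carbon, 1,3-thiazol-5-yl in place of phenyl gives an at least 52-fold lower number from compound 2 to compound 4 (1.72 log units; beyond the scatter) in this assay, the first step read at this place in the series. The figure is a bound and not a measured size, since compound 2 is only a limit of the assay: the limit of > 100000 nM in this assay, at which 1 of the 4 values shown sits.

Still, this place clearly responds to the ring it carries. Which ring atom, the nitrogen or the sulfur, goes with the step stays open. So does the outcome for a morpholine or a plain methyl on this carbonyl carbon.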